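This account rests on a few compounds, and the source may have more. Where it says the series, first, only, none or still open, it means among the compounds named here.

Compound 2, `CCOC(=O)C1=Cc2ccccc2OC1(OCc1cc(-c2ccc(OC)cc2)no1)C(F)(F)F`, is one of the two compounds already examined in a functional assay on A549 cells (Homo sapiens) for inhibition, read by MTT assay, with a stated time of 24 h; on this read-out lower numbers stand for stronger inhibition and higher numbers for weaker inhibition. In this assay compound 2 gives > 150000 nM, which is a limit of the assay and not a number. Compound 1, `CCOC(=O)C1=Cc2ccccc2OC1(OCc1cc(-c2ccc3ccccc3c2)no1)C(F)(F)F`, carries naphthalen-2-yl on an aromatic carbon where compound 2 carries 4-methoxyphenyl. In this assay compound 1 gives > 150000 nM, again a limit rather than a number. Within the data shown here, the single measured step, a step that the two limits leave unreadable from compound 1 to compound 2, therefore has no readable size, as the limit of > 150000 nM in this assay, at which 2 of the 2 values shown sit, makes plain.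

Compound 3, `CCOC(=O)C1=Cc2ccccc2OC1(OCc1cc(-c2cccc(C(F)(F)F)c2)no1)C(F)(F)F`, arises from compound 2 by the change (3-(trifluoromethyl)phenyl in place of 4-methoxyphenyl on an aromatic carbon), the new group sitting on an aromatic carbon of a five-membered aromatic ring with 1 nitrogen and 1 oxygen, next to the ring nitrogen. Among the measured compounds shown here, the one measured step concerns a swap of the group on that aromatic carbon and is itself unreadable, so no size can be carried over to this assay. Compound 3 is accordingly expected to sit again at or beyond the limit, with an estimate of 200000 nM and a range from 100000 nM to 600000 nM. The step this estimate implies is a step that the limit leaves unreadable from compound 2 to compound 3, expected to be none beyond the scatter.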

Compound 3, half-maximal inhibitory concentration: 48600 nM
For compound 3 the middle estimate is 4.1-fold (0.61 log units) above the measured one, outside the stated range (below it).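

In this assay, among these compounds, the aromatic carbon next to the ring nitrogen is the first place where a change of group gives a readable result: 3-(trifluoromethyl)phenyl in place of 4-methoxyphenyl gives an at least 3.0-fold lower number from compound 2 to compound 3 (0.48 log units; beyond the scatter). The same group in place of naphthalen-2-yl gives an at least 3.0-fold lower number from compound 1 to compound 3 (0.48 log units; beyond the scatter), so this position is not indifferent to what it carries, and of the three groups shown there only 3-(trifluoromethyl)phenyl brings the number off the limit. Both steps are bounds and not full sizes, as each starts from a compound held at a limit of the assay: the limit of > 150000 nM in this assay, at which 2 of the 3 values shown sit.

From the compounds shown here alone, what a plain phenyl, or a phenyl carrying a nitrile or a carboxylic acid, would give at this carbon stays open, and with it whether the step belongs to the trifluoromethyl group itself or to the loss of the other two groups. Also open, going by these compounds, is whether a change elsewhere on the shared core, such as an amide in place of the ethyl ester, would shift compound 3 from its 48600 nM.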